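Series notes: benzyl swap on the triazole of compound 2

The source may report more compounds than this note shows. Statements on the series, on what has been measured and on what is new or still open speak of the compounds shown alone.

Measured:
compound 1 `COc1cc(Cn2cc(CNC(=O)c3cn(-c4ccccc4)nc3-c3ccc(F)cc3)nn2)cc(OC)c1` — 2500 nM
compound 2 `COc1ccc(-c2nn(-c3ccccc3)cc2C(=O)NCc2cn(Cc3ccc(C(F)(F)F)cc3)nn2)cc1` — > 100000 nM

In a functional assay on MCF7 cells (Homo sapiens) for antiproliferative activity, read by sulforhodamine B assay, with a stated time of 48 h (a lower number here means a stronger inhibitor of growth, a higher number a weaker inhibitor of growth), compound 1 gives 2500 nM. For compound 2 the result is a limit only, > 100000 nM, as shown by the limit of > 100000 nM in this assay, at which 1 of the 2 values shown sits; compound 2 therefore stands at the edge of what this assay reports, with no number of its own.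

Compound 3 `COc1ccc(-c2nn(-c3ccccc3)cc2C(=O)NCc2cn(Cc3cc(OC)cc(OC)c3)nn2)cc1` is not yet measured. It differs from compound 2 by 3,5-dimethoxyphenyl in place of 4-(trifluoromethyl)phenyl on a saturated chain carbon bound to an aromatic nitrogen. Within the data shown here, no measured pair covers this change, so the size of the step rests on expectation alone. A step in this assay from the limit of compound 2 towards a measurable number is expected, in the direction of stronger growth inhibition and beyond the scatter, though the chance that compound 3 again returns only a limit is not small. For compound 3 the expected step is an at least 5.0-fold lower number from compound 2 to compound 3 (0.69 log units; beyond the scatter). Compound 3 is estimated at 20000 nM, within 3000 nM to 100000 nM.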

Compound 3, concentration for 50% growth inhibition: 700 nM
Estimate against measurement, compound 3: 29-fold (1.46 log units) above; the measured number lies below the stated range.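

In this assay, 3,5-dimethoxyphenyl in place of 4-(trifluoromethyl)phenyl on a saturated chain carbon bound to an aromatic nitrogen gives an at least 140-fold lower number from compound 2 to compound 3 (2.15 log units; beyond the scatter), so this one place alone takes the series from a limit to a measurable number. That step gives only a bound on the size of the change, as compound 2 stands at a limit: the limit of > 100000 nM in this assay, at which 1 of the 3 values shown sits. With 3,5-dimethoxyphenyl held fixed, methoxy in place of fluoro on an aromatic carbon gives a 3.6-fold lower number from compound 1 to compound 3 (0.55 log units; beyond the scatter), a modest step that shows the number also responds to a second place in the molecule.

Open, going by these compounds, is whether an unsubstituted phenyl, a single methoxy or an amine at the first place would read as a number or as a limit. Also open, on these data alone, is whether the methoxy to fluoro swap moves the number the same way with 4-(trifluoromethyl)phenyl in place.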